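Moving a hydroxyl group: from compound 3 to compound 4

The compounds below may be only part of what the source reports. "The series", "measured", "known", "first", "only" and "open" are said of these compounds alone.

compound 1 `Cc1cc(C)cc(S(=O)(=O)c2c(C(=O)Nc3ccc(O)cc3)[nH]c3ccc(Cl)cc23)c1` – 18100 nM
compound 2 `Cc1cc(C)cc(S(=O)(=O)c2c(C(=O)NCc3ccc(O)cc3)[nH]c3ccc(Cl)cc23)c1` – 6250 nM
compound 3 `Cc1cc(C)cc(S(=O)(=O)c2c(C(=O)NCC(=O)NCc3ccccc3O)[nH]c3ccc(Cl)cc23)c1` – > 47300 nM (a limit of the assay, not a number)

These values come from an ADME assay on MT4 cells (Homo sapiens) for cytotoxicity, read by MTT assay (a lower number here means that less compound is tolerated, a higher number that more compound is tolerated), and show how much compound the cells tolerate. Compound 3 stands at the top of this small set, and its > 47300 nM is a limit rather than a number.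

Compound 4 `Cc1cc(C)cc(S(=O)(=O)c2c(C(=O)NCC(=O)NCc3cccc(O)c3)[nH]c3ccc(Cl)cc23)c1` has the same atoms as compound 3, joined differently. The change is 3-hydroxyphenyl in place of 2-hydroxyphenyl on a saturated chain carbon bound to an amide-type nitrogen and amounts to 3-hydroxyphenyl in place of 2-hydroxyphenyl on a saturated chain carbon bound to an amide-type nitrogen.

Among the compounds with values here, no measured step moves the hydroxyl group alone. The nearest evidence concerns the side chain as a whole. There is a 2.9-fold lower number from compound 1 to compound 2 (0.46 log units; beyond the scatter) for the 4-hydroxybenzyl swap, and both an at least 2.6-fold higher number from compound 1 to compound 3 (0.41 log units; beyond the scatter) and an at least 7.5-fold higher number from compound 2 to compound 3 (0.87 log units; beyond the scatter) go with the carbamoyl chain, which compound 4 keeps. The hydroxyl position differs in those last two steps as well, so they say little about this move by itself.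

No step beyond the usual scatter is therefore expected in this assay and no direction is favoured. The estimated change, an at least 1.0-fold lower number from compound 3 to compound 4 (0.02 log units; that floor lies within the scatter) in size, is expected to be small. Compound 4 is expected at 45000 nM with an estimated range of 20000 nM to 90000 nM in repeated measurements.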

Compound 4, half-maximal cytotoxic concentration: > 47500 nM
Compound 4: only a limit was reported; the forecaster's own chance of this, stated with the estimate: 55%; middle value at least 1.0-fold (0.02 log units) away from the limit.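

In this assay compound 4 gives > 47500 nM, a limit of the assay and not a number, and compound 3 also stands at a limit, so the step between them cannot be read. The steps from the two shorter amides can be read: there is an at least 7.6-fold higher number from compound 2 to compound 4 (0.88 log units; beyond the scatter), and there is an at least 2.6-fold higher number from compound 1 to compound 4 (0.41 log units; beyond the scatter). The high tolerance that went with the carbamoyl chain in compound 3 therefore also appears in compound 4, so among these compounds it does not depend on having 2-hydroxyphenyl rather than 3-hydroxyphenyl at the end of that chain.

From the compounds shown here alone, with both values stopping at limits, it remains open how much of either compound the cells would tolerate, and whether the hydroxyl position makes any difference at all in this assay. Also open, going by these compounds, is whether the carbamoyl chain keeps this tolerance with a 4-hydroxybenzyl group at its end, or when an amine or a carboxylic acid takes the place of the hydroxyl.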